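Methyl for Methoxy: One Change Made on Two Cores

The source may report more compounds than this note shows. Statements on the series, on what has been measured and on what is new or still open speak of the compounds shown alone.

Three compounds were examined in an ADME assay on HEK293 cells (Homo sapiens) for antiproliferative activity, read by MTT assay, with a stated time of 24 h; on this read-out lower numbers stand for stronger inhibition and higher numbers for weaker inhibition. Compound 1 `COc1ccc(C(=O)/C=C/c2cc(-c3cc(OC)c(OC)c(OC)c3)n3nc(-c4ccccc4)cc3n2)cc1` gave 79800 nM in this assay, compound 2 `COc1cc(-c2cc(/C=C/C(=O)c3ccc(C)cc3)nc3cc(-c4ccccc4)nn23)cc(OC)c1OC` gave 50400 nM, and compound 3 `COc1ccc(/C=C/C(=O)c2cc(-c3cc(OC)c(OC)c(OC)c3)n3nc(-c4ccccc4)cc3n2)cc1` gave 46600 nM.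

Compound 2 arises from compound 1 by a single change, (methyl in place of methoxy on an aromatic carbon), and this went with a 1.6-fold lower number from compound 1 to compound 2 (0.20 log units; within the scatter). Compound 3 has the same atoms as compound 1, joined differently: (2-(4-methoxyphenyl)ethenyl)carbonyl in place of 2-((4-methoxyphenyl)carbonyl)ethenyl on an aromatic carbon. That rearrangement of the core gave a 1.7-fold lower number from compound 1 to compound 3 (0.23 log units; within the scatter). Between the remaining pair there was a 1.1-fold lower number from compound 2 to compound 3 (0.03 log units; within the scatter). All three numbers thus sit close together, and none of the compounds can be set apart from the others on this read-out.

Compound 4 `COc1cc(-c2cc(C(=O)/C=C/c3ccc(C)cc3)nc3cc(-c4ccccc4)nn23)cc(OC)c1OC` has not yet been measured in this assay. It arises from compound 3 by methyl in place of methoxy on an aromatic carbon. This is the same change that turns compound 1 into compound 2, made here on the core of compound 3 rather than on that of compound 1; the surroundings of the changed position read alike in both cases, so it counts as the same change on a different core. Given a 1.6-fold lower number from compound 1 to compound 2 (0.20 log units; within the scatter), a step of similar and small size is expected: a 1.3-fold lower number from compound 3 to compound 4 (0.11 log units; within the scatter). Compound 4 is accordingly expected to give about 36000 nM in this assay, with a likely range from 15000 nM to 90000 nM.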

Compound 4, half-maximal inhibitory concentration: 56100 nM
Compound 4: the middle estimate sits 1.6-fold (0.19 log units) below what was measured; low and high end bracket the measured number.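

In this assay, methyl in place of methoxy on the core of compound 3 went with a 1.2-fold higher number from compound 3 to compound 4 (0.08 log units; within the scatter). The two other new steps, a 1.1-fold higher number from compound 2 to compound 4 (0.05 log units; within the scatter) and a 1.4-fold lower number from compound 1 to compound 4 (0.15 log units; within the scatter), are also small, so compound 4 cannot be set apart from any of the other three compounds on this read-out. Set beside the same change on the core of compound 1, the new step cannot be told from the earlier one: the same change on two cores in this assay, a 1.6-fold lower number (0.20 log units; within the scatter) from compound 1 to compound 2 and a 1.2-fold higher number (0.08 log units; within the scatter) from compound 3 to compound 4, 1.9-fold (0.28 log units) apart, within the scatter of two such steps. Among the compounds shown here, this shows that the change went with only a small step on both cores, but it does not show that a step of fixed size or direction carries from one core to the other, as neither step can be told from the scatter and the two pairs offer only this one comparison.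

The compounds shown carry only methoxy or methyl at this place, so it remains open what an amine, a carboxylic acid or a longer chain there would do to the read-out. From the compounds shown here alone, it also remains open whether methyl in place of methoxy would give a step beyond the scatter on any further core.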